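This account rests on a few compounds, and the source may have more. Where it says the series, first, only, none or still open, it means among the compounds named here.

Working notes on the series, read in an ADME assay, at pH 3; a lower number here means that the compound disappears faster, a higher number that the compound lasts longer. Compound 1 (`COc1cnc(C[S+]([O-])c2nc3cc(OC(F)F)ccc3[nH]2)c(C)c1OC`) gives 0.2 h, and compound 2 (`COc1c(C)cnc(C[S+]([O-])c2nc3cc(OC(F)F)ccc3[nH]2)c1C`) gives 0.2 h, so the two sit level, with no change at the digits printed from compound 1 to compound 2 (within the scatter). Compound 3 (`COc1ccnc(C[S+]([O-])c2nc3cc(OC(F)F)ccc3[nH]2)c1C`) gives 0.0833 h, lower than both, with a 2.4-fold lower number from compound 1 to compound 3 (0.38 log units; beyond the scatter) and a 2.4-fold lower number from compound 2 to compound 3 (0.38 log units; beyond the scatter). Compound 1 thus shares the upper level of this small set with compound 2.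

Compound 4 (`COc1cnc(C[S+]([O-])c2nc3cc(OC(F)(F)C(F)F)ccc3[nH]2)c(C)c1OC`) has not been measured yet. Its change from compound 1 is difluoromethyl in place of hydrogen on a saturated chain carbon bound to two fluorine atoms and an oxygen on an aromatic ring, which turns difluoromethoxy into 1,1,2,2-tetrafluoroethoxy. The three measured steps bear on it only indirectly. All of them exchange methoxy, methyl or hydrogen on an aromatic carbon, and none alters the difluoromethoxy group. Among the compounds with values here, the series therefore offers no direct precedent and no direction for this change, while the steps seen elsewhere are no larger than modest.

No step beyond the scatter is expected, and the estimated change is no change at the digits printed from compound 1 to compound 4 (within the scatter). Compound 4 is expected at 0.2 h, with an estimated range from 0.1 h to 0.4 h.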

Compound 4, half-life: 0.333 h
Compound 4: the middle estimate sits 1.7-fold (0.22 log units) below what was measured; low and high end bracket the measured number.
By their numbers in this assay, from the lowest: compound 3; then compounds 1, 2 and 4 (each within the scatter of the next).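

In this assay, the step at the saturated chain carbon bound to two fluorine atoms and an oxygen on an aromatic ring reads a 1.7-fold higher number from compound 1 to compound 4 (0.22 log units; within the scatter). Within the data shown here, this is the first reading of a change in the difluoromethoxy group, as the earlier steps all exchanged methoxy, methyl or hydrogen on an aromatic carbon, and it shows that turning difluoromethoxy into 1,1,2,2-tetrafluoroethoxy on the core of compound 1 gives no separation beyond the scatter, so this single exchange sets no direction at this position. No measurement at hand explains this reading.

A single exchange on a single core leaves open whether difluoromethyl in place of hydrogen at this carbon would read the same way on the cores of compound 2 and compound 3, where the aromatic substituents differ. It also leaves open how trifluoromethoxy, plain methoxy, ethoxy or a longer fluorinated chain would read in place of difluoromethoxy, and thus whether any group at this position can move the number beyond the scatter.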